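A few compounds are considered here, and "the series" means these few. Any claim that something is new, unique, unknown or untested is made for them only; others in the source may bear on it.

Measured compounds in a functional assay on HeLa cells (Homo sapiens) for inhibition, read by cell counting, with a stated time of 4 days; a lower number here means a stronger inhibitor, a higher number a weaker inhibitor:
compound 1, `C=C(Br)C(=O)Nc1cccc(-c2cn3nc(Cc4cccc(OC)c4)sc3n2)c1`, gives 2500 nM
compound 2, `C=C(Br)C(=O)Nc1cccc(-c2cn3nc(CCc4ccccc4)sc3n2)c1`, gives 3300 nM
compound 3, `C=C(Br)C(=O)Nc1cccc(-c2cn3nc(-c4ccc(F)cc4)sc3n2)c1`, gives 870 nM

Compound 3 stands lowest of the three numbers in this assay. Its nearest neighbour is compound 1, at a 2.9-fold lower number from compound 1 to compound 3 (0.46 log units; beyond the scatter), and its furthest is compound 2, at a 3.8-fold lower number from compound 2 to compound 3 (0.58 log units; beyond the scatter). Both steps lie beyond the scatter, so compound 3 is the strongest inhibitor of the three. The step between compound 1 and compound 2, a 1.3-fold higher number from compound 1 to compound 2 (0.12 log units; within the scatter), lies within the scatter.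

Compound 4, `C=C(Br)C(=O)Nc1cccc(-c2cn3nc(-c4cccc(OC)c4)sc3n2)c1`, is not yet measured. It differs from compound 3 as follows: 3-methoxyphenyl in place of 4-fluorophenyl on an aromatic carbon. The ring that enters is the same one compound 1 carries on a saturated chain carbon; in compound 4 it is bound directly to the aromatic carbon, as the 4-fluorophenyl is in compound 3. Among the compounds with values here, the two measured steps that bear on this, a 2.9-fold lower number from compound 1 to compound 3 (0.46 log units; beyond the scatter) and a 3.8-fold lower number from compound 2 to compound 3 (0.58 log units; beyond the scatter), both concern the exchange of a 3-methoxybenzyl or phenethyl group for a directly bound ring, not the exchange of one directly bound ring for another; no measured step separates the two rings themselves. Compound 4 keeps the direct attachment, so its number is expected to stay close to that of compound 3, the direction left open. The step expected in this assay is a 1.3-fold higher number from compound 3 to compound 4 (0.10 log units; within the scatter), within the scatter. Compound 4 is therefore estimated at 1100 nM, with a range from 400 nM to 3000 nM.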

Compound 4, half-maximal inhibitory concentration: 1100 nM
For compound 4 middle estimate and measured number coincide at the digits printed; the range from low to high includes it.
By their numbers in this assay, from the lowest: compounds 3 and 4 (each within the scatter of the next); then compounds 1 and 2 (each within the scatter of the next).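

In this assay, exchanging one directly bound ring for the other on this aromatic carbon gives a 1.3-fold higher number from compound 3 to compound 4 (0.10 log units; within the scatter) and so separates 4-fluorophenyl from 3-methoxyphenyl by no more than the scatter, even though the entering group carries one hydrogen-bond acceptor and the leaving group none. Within the data shown here, the earlier advantage of a directly bound ring over a chain-linked group now holds for a second ring, with a 3.0-fold lower number from compound 2 to compound 4 (0.48 log units; beyond the scatter) against phenethyl and a 2.3-fold lower number from compound 1 to compound 4 (0.36 log units; beyond the scatter) against 3-methoxybenzyl, the latter being the first step in which the same substituted ring sits either directly on the aromatic carbon or on a saturated chain carbon. Across these four compounds, the two directly bound rings therefore form the lower pair and the two chain-linked groups the higher pair, but no supporting measurement explains either the gap or the absence of a difference between the two rings.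

Still open, on these data alone, is whether the position needs an aromatic ring at all, as a directly bound amine or carboxylic acid would test. Also open, as far as these compounds go, is how an unsubstituted phenyl compares with these two rings, and whether a longer chain would raise the number further.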